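This account rests on a few compounds, and the source may have more. Where it says the series, first, only, none or still open, it means among the compounds named here.

Measured so far in a functional assay on MCF7 cells (Homo sapiens) for antiproliferative activity, read by CellTiter-Glo, with a stated time of 5 days (a higher number here means a weaker inhibitor, a lower number a stronger inhibitor), are these compounds:
compound 1 `CC/C(=C(/c1ccc(/C=C/C(=O)O)cc1)c1ccc2c(cnn2C)c1)c1ccc(F)cc1Cl` gives 81 nM
compound 2 `CC/C(=C(/c1ccc(/C=C/C(=O)O)cc1)c1ccc2cncn2c1)c1ccccc1` gives > 500 nM (a limit)
compound 3 `CC/C(=C(/c1ccc(/C=C/C(=O)O)cc1)c1ccc2scnc2c1)c1ccccc1` gives 90 nM

Compound 2 has no number in this assay and stands only at the limit > 500 nM as its reading.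

Compound 4 `CC/C(=C(/c1ccc(/C=C/C(=O)O)cc1)c1ccc2ocnc2c1)c1ccccc1` is still unmeasured. The structural change is a group of 9 heavy atoms (7 carbon, 1 nitrogen, 1 oxygen; one five-membered aromatic ring with 2 hetero atoms, one six-membered aromatic ring of carbon only) in place of a group of 9 heavy atoms (7 carbon, 2 nitrogen; one five-membered aromatic ring with 2 hetero atoms, one six-membered aromatic ring with 1 hetero atom), on a double-bonded chain carbon bound to an aromatic carbon and a double-bonded chain carbon and it lies on a double-bonded chain carbon bound to an aromatic carbon and a double-bonded chain carbon. The entering 1,3-benzoxazol-5-yl has one six-membered aromatic ring of carbon only, while the group that leaves has one six-membered aromatic ring with 1 hetero atom.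

Within the data shown here, one measured step bears on this change. It is an at least 5.5-fold lower number from compound 2 to compound 3 (0.74 log units; beyond the scatter) and it lies beyond the scatter. The group entering in that step, at the same place, also has one six-membered aromatic ring of carbon only. With this single step as the guide, a move of similar size towards a lower number is expected in this assay, and the start of that move is known only as a limit. The expected step is an at least 4.1-fold lower number from compound 2 to compound 4 (0.61 log units; beyond the scatter) and it rests on that one precedent. For compound 4 the estimate is 120 nM with an expected range from 45 nM to 350 nM as the working interval.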

Compound 4, half-maximal inhibitory concentration: > 500 nM
Compound 4: no number, only a limit; the forecaster's own chance of this, stated with the estimate: 12%; middle value at least 4.1-fold (0.61 log units) away from the limit.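

In this assay compound 4 gives > 500 nM, which is a limit of the assay and not a number. The readable step is an at least 5.5-fold higher number from compound 3 to compound 4 (0.74 log units; beyond the scatter), so at this double-bonded chain carbon 1,3-benzoxazol-5-yl does not stand in for 1,3-benzothiazol-5-yl, and a six-membered aromatic ring of carbon only is not enough on its own to give a reading like that of compound 3. The step between compound 2 and compound 4 cannot be read, since both readings sit at the same limit: the limit of > 500 nM in this assay, at which 2 of the 4 values shown sit.

Still open, as far as these compounds go, is how far compound 4 lies past its limit, and so how large the change from sulfur to oxygen in this group really is. Also open, from the compounds shown here alone, is whether an amine or a methyl group on the 1,3-benzothiazol-5-yl would keep a reading near that of compound 3, which gives 90 nM in this assay.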